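The source may report more compounds than this note shows. Statements on the series, on what has been measured and on what is new or still open speak of the compounds shown alone.

In a functional assay on B16-F10 cells (Mus musculus) for antiproliferative activity, read by ELISA and MTT assay, with a stated time of 48 h (on this read-out higher numbers stand for weaker inhibition and lower numbers for stronger inhibition), compound 1 `O=C(/C=C/c1ccccc1)NS(=O)(=O)c1ccc(Br)cc1` gives 3.9 ug/mL, and compound 2 `Cc1ccc(S(=O)(=O)NC(=O)/C=C/c2ccc(Cl)cc2)cc1` gives 4.6 ug/mL. Of these two numbers, compound 2 carries the one that sits within the usual scatter of compound 1, so the two cannot be told apart. Compound 3 `O=C(/C=C/c1ccc(Cl)cc1)NS(=O)(=O)c1ccc(Br)cc1` differs from compound 2 in one place: bromo in place of methyl on an aromatic carbon. Within the data shown here, no measured pair shows this same change, so there is no step to lean on, and in this assay no move beyond the scatter is expected. For compound 3 the estimate is 4.3 ug/mL, with a range from 2 ug/mL to 9 ug/mL, which means an expected step of a 1.1-fold lower number from compound 2 to compound 3 (0.03 log units; within the scatter).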

Compound 3, half-maximal inhibitory concentration: 2.8 ug/mL
Compound 3: middle estimate off by 1.5-fold (0.19 log units), on the high side, within the range that was stated.
By their numbers in this assay, from the lowest: compounds 3, 1 and 2 (each within the scatter of the next).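

In this assay, going from 4-methylphenyl to 4-bromophenyl gives only a small step (a 1.6-fold lower number from compound 2 to compound 3 (0.22 log units; within the scatter)), so bromo and methyl on this aromatic carbon cannot be told apart here. Chloro in place of hydrogen on the other aromatic ring also stays within the scatter (a 1.4-fold lower number from compound 1 to compound 3 (0.14 log units; within the scatter)), so neither single change gives a clear shift in this assay. Nothing measured here explains either step. From the compounds shown here alone, whether a very different group on the bromo-bearing carbon, such as an amine or a carboxylic acid, would move the number beyond the scatter remains open.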